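Phenyl for Oxadiazolyl on the Oxime Carbon

The source may hold more compounds than are shown below. What is called first, only, known or untested is meant among the compounds shown, and "the series" means these compounds.

The compounds share a benzothiazole-bearing oxime core, represented first by compound 1 `O/N=C/c1nc2ccccc2s1`, for which an ADME assay on CHO cells (Cricetulus griseus) for cytotoxicity (on this read-out lower numbers stand for stronger inhibition and higher numbers for weaker inhibition), records "not determined" (no result reported). Compound 2 `Cc1nc(/C(=N\O)c2nc3ccccc3s2)no1` is the starting point of the step followed here, and in this assay compound 2 likewise has "not determined" (no result reported), so it stands nowhere on the numbers shown and offers no anchor. Among the measured compounds shown here, compound 3 `O/N=C(\c1ccc2ncsc2c1)c1nc2ccccc2s1` is the only member with an entry, and in this assay compound 3 returns only a limit, > 50000 nM, which is not a number. Compound 3 thus sits at the limit of > 50000 nM in this assay, at which 1 of the 3 values shown sits. Compound 4 `O/N=C(\c1ccccc1)c1nc2ccccc2s1` differs from compound 2 by phenyl in place of 5-methyl-1,2,4-oxadiazol-3-yl on a carbon with a double bond to nitrogen. For the measured compounds named here, with no measured step among the three compounds, no shift beyond the usual scatter in this assay can be expected in either direction for this exchange. Compound 4 is therefore estimated at 60000 nM, within a range from 20000 nM to 200000 nM, with a fair chance that only a limit is reported.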

Compound 4, half-maximal inhibitory concentration: > 100000 nM
Compound 4 gave a limit, no number; the forecaster's own chance of this, stated with the estimate: 70%; at least 1.6-fold (0.22 log units) between middle value and limit.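

In this assay compound 4 gives > 100000 nM, a limit and not a number. Among the compounds shown here, with no single number for compound 2 either, no step between compound 2 and compound 4 can be read. The compounds shown leave open whether phenyl in place of 5-methyl-1,2,4-oxadiazol-3-yl changes the result in this assay at all.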